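The source may report more compounds than this note shows. Statements on the series, on what has been measured and on what is new or still open speak of the compounds shown alone.

Two compounds from this study share a common core. Compound 1 is `COc1ccc2nc(C)cc(OC3CCN(c4ccccc4)C3=O)c2c1` and compound 2 is `COc1ccc2nc(C)cc(OCC(=O)Nc3cc(C)ccc3C)c2c1`. In a toxicity assay on HepG2 cells (Homo sapiens) for inhibition, read by CellTiter-Glo, with a stated time of 48 h (on this read-out higher numbers stand for weaker inhibition and lower numbers for stronger inhibition), compound 1 gives 100000 nM. For compound 2 this assay returns only a limit, > 100000 nM, and not a number. That is the limit of > 100000 nM in this assay, at which 1 of the 2 values shown sits, so compound 2 stands at the upper edge of what this assay reports, and nothing more can be said about where its true value lies beyond that edge.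

The third member, compound 3, is `COc1ccc2nc(C)cc(OCC(=O)Nc3ccncc3)c2c1`, not yet tested in this assay. It differs from compound 2 in a single place: pyridin-4-yl in place of 2,5-dimethylphenyl on an amide-type nitrogen.

Among the compounds with values here, with no measured step between compounds that differ in one place, the expectation for compound 3 rests on the two values shown, both of which sit at or beyond the top of this assay. The step of a number no higher from compound 2 to compound 3 (the limit leaves the size open) is expected to be none beyond the usual scatter. Compound 3 is accordingly estimated at 100000 nM in this assay, with a plausible range from 40000 nM to 100000 nM, and a substantial chance that only a limit is reported again.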

Compound 3, half-maximal inhibitory concentration: > 100000 nM
Compound 3 ended at the assay's limit; the forecaster's own chance of this, stated with the estimate: 65%; the middle value lies on the limit itself.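

Within the data shown here, compound 2 and compound 3 both end at a limit and not at a number in this assay, so no step between them can be read: the limit of > 100000 nM in this assay, at which 2 of the 3 values shown sit.

The compounds shown leave open where the true values of compound 2 and compound 3 lie, and whether pyridin-4-yl in place of 2,5-dimethylphenyl makes any difference to this read-out.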